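The source may report more compounds than this note shows. Statements on the series, on what has been measured and on what is new or still open speak of the compounds shown alone.

Of the compounds shown here, two with much of their structure in common have been measured in a functional assay on PC-3 cells (Homo sapiens) for antiproliferative activity, read by MTT assay, with a stated time of 48 h; on this read-out lower numbers stand for stronger inhibition of growth and higher numbers for weaker inhibition of growth. In this test, compound 1 `CCOc1cc(NC(=O)CCCCCC(=O)Nc2cc(-c3ccccc3)ccc2N)cc2c1OCC([N+](=O)[O-])=C2` gives 7080 nM, while compound 2 `CCOc1cc(NC(=O)CCCCC(=O)Nc2cc(-c3ccccc3)ccc2N)cc2c1OCC([N+](=O)[O-])=C2` gives 14600 nM. Compound 2 therefore holds the higher number of the two, meaning weaker inhibition of growth, and its gap to compound 1 lies just beyond the usual scatter of repeated measurements.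

The next molecule, compound 3 `CCOc1cc(NC(=O)CCCCC(=O)Nc2cc(-c3ccc(C)s3)ccc2N)cc2c1OCC([N+](=O)[O-])=C2`, is compound 2 with a single group exchanged: 5-methylthiophen-2-yl in place of phenyl on an aromatic carbon. In plain terms, 5-methylthiophen-2-yl stands in place of phenyl on an aromatic carbon, para to an amino group and meta to a large group. Among the compounds with values here, no measured pair shows what this exchange does, so any forecast is uncertain. Starting from the 14600 nM of compound 2, a small shift toward stronger inhibition is expected in this assay, though it may not clear the scatter. The estimated change is a 1.6-fold lower number from compound 2 to compound 3 (0.21 log units; within the scatter). For compound 3 the expected value is 9000 nM, within an estimated range of 3000 nM to 25000 nM.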

Compound 3, concentration for 50% growth inhibition: 13500 nM
Estimate against measurement, compound 3: 1.5-fold (0.18 log units) below, and the stated range covers the measured number.
By their numbers in this assay, from the lowest: compounds 1, 3 and 2 (each within the scatter of the next, the first and the last beyond it).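

In this assay the exchange of phenyl for 5-methylthiophen-2-yl gives a 1.1-fold lower number from compound 2 to compound 3 (0.03 log units; within the scatter), so at this place, para to an amino group, the read-out does not tell the two groups apart. Compounds 1 and 2 differ only in their chain and said nothing about this position; compound 3 now shows that a six-membered aromatic ring of carbon only can give way to a five-membered aromatic ring with one sulfur and a methyl group, with no change beyond the scatter. Nothing measured here offers an explanation for how closely compound 2 and compound 3 agree.

From the compounds shown here alone, one exchange at one chain length is a narrow basis, so it remains open whether this position tolerates groups in general or whether these two simply happen to read alike, and whether a plain thiophen-2-yl, a pyridine ring or a phenyl bearing a carboxylic acid would give a different number here. Also open, going by these compounds, is whether 5-methylthiophen-2-yl would behave the same way on the longer chain of compound 1.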